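The source may hold more compounds than are shown below. What is called first, only, known or untested is meant among the compounds shown, and "the series" means these compounds.

Measured compounds in a functional assay on KB cells (Homo sapiens) for antiproliferative activity, read by MTT assay, with a stated time of 48 h; on this read-out lower numbers stand for stronger inhibition and higher numbers for weaker inhibition:
- compound 1 `Cn1cc(C2=C(c3n[nH]c4ncccc34)C(=O)NC2=O)c2ccccc21` gives 62000 nM
- compound 2 `Cn1cc(C2=C(c3nn(CCn4ccnc4)c4ncccc34)C(=O)NC2=O)c2ccccc21` reaches only the limit of the assay, > 100000 nM
- compound 3 `CN1CCN(CCCn2nc(C3=C(c4cn(C)c5ccccc45)C(=O)NC3=O)c3cccnc32)CC1` reaches only the limit of the assay, > 100000 nM

Where compound 3 stands: its value is a limit, not a number, so it sits at the ceiling of this assay together with compound 2 (the limit of > 100000 nM in this assay, at which 2 of the 3 values shown sit). The step from compound 1 to compound 3, 3-(4-methylpiperazin-1-yl)propyl in place of hydrogen on an aromatic nitrogen, is an at least 1.6-fold higher number from compound 1 to compound 3 (0.20 log units; that floor lies within the scatter). The step between the two substituted compounds is a step that the two limits leave unreadable from compound 2 to compound 3.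

Compound 4 `Cn1cc(C2=C(c3nn(CCCO)c4ncccc34)C(=O)NC2=O)c2ccccc21` is not yet measured. It differs from compound 3 as follows (hydroxy in place of 4-methylpiperazin-1-yl on a saturated chain carbon, three bonds along the chain from an aromatic nitrogen). Cut one bond further out the change reads 3-(4-methylpiperazin-1-yl)propyl to 3-hydroxypropyl, so compound 4 sits between compound 1 and compound 3 in the size of what hangs on the aromatic nitrogen.

Within the data shown here, no measured step bears on this change directly: the step from compound 2 to compound 3 is unreadable and the step from compound 1 to compound 3 only sets a floor within the scatter. Among the measured compounds shown here, the only number is that of compound 1, and both substituted compounds return a limit. For compound 4 a value near the limit is therefore expected, 90000 nM (35000 nM to 250000 nM), which is an estimated step of an at least 1.1-fold lower number from compound 3 to compound 4 (0.04 log units; that floor lies within the scatter).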

Compound 4, half-maximal inhibitory concentration: > 100000 nM
Compound 4 gave a limit, no number; the forecaster's own chance of this, stated with the estimate: 50%; at least 1.1-fold (0.04 log units) between middle value and limit.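

In this assay, the limit now also holds for a group with no ring: 3-hydroxypropyl, which has hydroxy with its single heavy atom in place of the 4-methylpiperazin-1-yl ring, gives no more readable a result than the two ring-bearing chains. Against the unsubstituted core the change is an at least 1.6-fold higher number from compound 1 to compound 4 (0.20 log units; that floor lies within the scatter), so this third substituent on the aromatic nitrogen again sets only a floor, and the steps among the three substituted compounds cannot be read. The series now collects at one ceiling, with compound 1 the only compound that goes against it:  the limit of > 100000 nM in this assay, at which 3 of the 4 values shown sit.

As far as these compounds go, it remains open whether any group on this aromatic nitrogen truly weakens the read-out, as every floor from compound 1 lies within the scatter. Among these compounds, compound 1 itself gives 62000 nM, the only number. A methyl group on the same nitrogen, or a propyl chain ending in a primary amine or a carboxylic acid, could show whether a number can be obtained at this position at all.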